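The compounds below may be only part of what the source reports. "The series", "measured", "known", "first", "only" and "open" are said of these compounds alone.

Measured compounds in a functional assay on BGC-823 cells (Homo sapiens) for cytotoxicity, read by MTT assay; on this read-out higher numbers stand for weaker inhibition and lower numbers for stronger inhibition:
- compound 1 `Cc1ccccc1Nc1nc(C)c(C(=O)/C=C/c2ccc(Cl)cc2)s1`: > 25000 nM, a limit of the assay, not a number.
- compound 2 `Cc1nc(Nc2cccc(Cl)c2)sc1C(=O)/C=C/c1ccc(Cl)cc1`: > 25000 nM, likewise a limit of the assay.
- compound 3 `COc1cc(/C=C/C(=O)c2sc(Nc3cccc(Cl)c3)nc2C)cc(OC)c1OC`: 11600 nM.

Among the measured compounds shown here, compound 3 holds the only numerical value in this assay; the other two results are limits, as noted under (the limit of > 25000 nM in this assay, at which 2 of the 3 values shown sit). For the measured compounds named here, the one measured step with a change on the nitrogen on the aromatic ring, a step that the two limits leave unreadable from compound 1 to compound 2, is unreadable because both ends sit at the limit, so its size gives no guidance.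

Compound 4 `COc1cc(/C=C/C(=O)c2sc(Nc3ccc(C)cc3)nc2C)cc(OC)c1OC` differs from compound 3 by 4-methylphenyl in place of 3-chlorophenyl on a nitrogen on an aromatic ring. Going by the values given here, no measured step in this assay reads the effect of such an exchange, so the expectation rests on compound 3 alone. The step from compound 3 to compound 4 is expected to stay within the scatter, a 1.3-fold higher number from compound 3 to compound 4 (0.11 log units; within the scatter), with a real chance that compound 4 reports only a limit. For compound 4 the estimated value in this assay is 15000 nM, within the range 5000 nM to 40000 nM.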

Compound 4, half-maximal inhibitory concentration: > 25000 nM
Compound 4 gave a limit, no number (the forecaster's own chance of this, stated with the estimate: 35%); at least 1.6-fold (0.22 log units) between middle value and limit.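

In this assay, the series now has its first readable step at this position: an at least 2.1-fold higher number from compound 3 to compound 4 (0.33 log units; beyond the scatter). Among the compounds shown here, the earlier change on this nitrogen could not be read, so this is the first sign that the group here matters on the core of compound 3, although the size of the step is only a lower bound. Compound 3 remains the only compound with a numerical value, and the rest of the series sits at one limit: the limit of > 25000 nM in this assay, at which 3 of the 4 values shown sit.

This single exchange changes both the substituent and its place on the ring, so the data cannot separate the loss of chlorine from the gain of methyl or from the change of place. Also open, from the compounds shown here alone, is how a 3-methylphenyl or a 4-chlorophenyl group on this nitrogen would read on the core of compound 3, which would help to separate these two changes.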